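The source may hold more compounds than are shown below. What is called first, only, known or untested is meant among the compounds shown, and "the series" means these compounds.

In an ADME assay on the whole organism (Rattus norvegicus, strain Sprague-Dawley) for pharmacokinetics, read by LC-MS, with a stated time of 30 min, at a dose of 1 mg/kg by the intravenous route (a lower number here means slower removal, a higher number faster removal of the compound), compound 1 `N#Cc1ccc(S(=O)(=O)[C@H]2CN(S(=O)(=O)c3ccc(Cl)cc3Cl)C[C@@]2(O)CO)cc1` gives 25 mL/min/kg and compound 2 `N#Cc1ccc(S(=O)(=O)[C@H]2CN(S(=O)(=O)c3ccc(Cl)cc3Cl)C[C@@]2(O)CO)cc1F` gives 25 mL/min/kg, so the two stand level. Compound 3 `N#Cc1ccc(S(=O)(=O)[C@H]2CN(S(=O)(=O)c3ccc(Cl)cc3C#N)C[C@@]2(O)CO)cc1` keeps the core of compound 1 and differs from it in one place: cyano in place of chloro on an aromatic carbon. Cyano takes the place of chloro on an aromatic carbon, ortho to a large group, so 2,4-dichlorophenyl becomes 4-chloro-2-cyanophenyl. Among the compounds with values here, only one measured step offers any guide: no change at the digits printed from compound 1 to compound 2 (within the scatter), with fluoro in place of hydrogen on an aromatic carbon. Within the data shown here, that is a different swap, and no measured pair shows what replacing chloro with cyano does, so the evidence is thin. With that single flat step as the guide, no shift beyond the scatter is expected, in either direction. The expected step is a 1.1-fold lower number from compound 1 to compound 3 (0.06 log units; within the scatter). For compound 3 the estimated clearance is 22 mL/min/kg, with an expected range from 11 mL/min/kg to 45 mL/min/kg.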

Compound 3, clearance: 82 mL/min/kg
The estimate for compound 3 lay 3.7-fold (0.57 log units) below the measured number, outside the stated range (above it).
By their numbers in this assay, from the lowest: compounds 1 and 2 (each within the scatter of the next); then compound 3.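

Cyano in place of chloro gives a 3.3-fold higher number from compound 1 to compound 3 (0.52 log units; beyond the scatter) in this assay, so this measure of removal does respond to a change at this place, ortho to a large group. The earlier step, fluoro in place of hydrogen, gave no change at the digits printed from compound 1 to compound 2 (within the scatter) and showed no such response. The 2,4-dichlorophenyl group therefore cannot be treated as a part of the molecule that leaves clearance untouched when altered, although nothing at hand says why the number rises.

The compounds shown leave open whether the rise belongs to the incoming cyano group or to the loss of chloro at this place, and whether the remaining chloro group matters in the same way. A methyl or methoxy group at the same place would help to separate these readings.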